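A few compounds are considered here, and "the series" means these few. Any claim that something is new, unique, unknown or untested is made for them only; others in the source may bear on it.

Going by the values given here, compound 2 `CCCCCCCCCCCCCCCC(=O)Nc1ccn([C@@H]2CO[C@H](CO)O2)c(=O)n1` gives 4 nM in a functional assay on A549 cells (Homo sapiens) for cytotoxicity, read by sulforhodamine B assay, with a stated time of 72 h (a higher number here means a weaker inhibitor, a lower number a stronger inhibitor), the lowest of the two numbers measured so far. Its nearest neighbour, compound 1 `CCCCCCCCC(=O)Nc1ccn([C@@H]2CO[C@H](CO)O2)c(=O)n1`, gives 46 nM in this assay. Among the compounds with values here, the single measured step between them, a 12-fold lower number from compound 1 to compound 2 (1.06 log units; beyond the scatter), is large, and it is the only step that bears on the question here. Compound 3 `CCCCCCCCCCCCCCCCCCCCCC(=O)Nc1ccn([C@@H]2CO[C@H](CO)O2)c(=O)n1` carries the same kind of change taken one stage further: hexyl in place of hydrogen on a saturated chain carbon, ten or more bonds along the chain from a carbonyl carbon. Whether a second lengthening of the chain brings as much gain as the first cannot be told from one step, so the expected change is a modest one, a 1.3-fold lower number from compound 2 to compound 3 (0.12 log units; within the scatter), an expectation that rests on a 12-fold lower number from compound 1 to compound 2 (1.06 log units; beyond the scatter) alone and on nothing else in the data. For compound 3 in this assay the estimated value is therefore 3 nM, with a likely range from 1 nM to 15 nM.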

Compound 3, half-maximal inhibitory concentration: 500 nM
For compound 3 the middle estimate is 170-fold (2.22 log units) below the measured one; the measured number lies above the stated range.
By their numbers in this assay, from the lowest: compound 2; then compound 1; then compound 3.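

In this assay lengthening the chain does not keep lowering the number: hexyl in place of hydrogen on a saturated chain carbon gives a 130-fold higher number from compound 2 to compound 3 (2.10 log units; beyond the scatter) and undoes the earlier gain of a 12-fold lower number from compound 1 to compound 2 (1.06 log units; beyond the scatter) in this short series. Chain length therefore acts here as a turn and not as a steady trend, with compound 2 at the lowest number of the three. Compound 1 gives 46 nM while compound 3 gives 500 nM in the same assay, so the longest chain shown carries a higher number than the shortest.

Still open, on these data alone, is where the turn lies, at a chain longer than that of compound 2 but shorter than that of compound 3, and how a chain ending in an amine or a carboxylic acid would behave. No measurement shown explains why the number rises so sharply.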